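This account rests on a few compounds, and the source may have more. Where it says the series, first, only, none or still open, it means among the compounds named here.

Compound 1 `COc1ccc(-c2cn3cc(C4=CCN(C(=O)c5ccc(Cl)cc5)CC4)ccc3n2)cc1OC` gives 8970 nM in a functional assay on A549 cells (Homo sapiens) for antiproliferative activity, read by MTT assay, with a stated time of 48 h; a lower number here means a stronger inhibitor, a higher number a weaker inhibitor.
Compound 2 `COc1ccc(-c2cn3cc(C4=CCN(S(=O)(=O)C5CCCCC5)CC4)ccc3n2)cc1OC` gives 4490 nM in this assay.
Compound 3 `COc1ccc(-c2cn3cc(C4=CCN(C(=O)C5CC5)CC4)ccc3n2)cc1OC` gives 9140 nM in this assay.

All three compounds share one core and differ only in the group carried on an amine nitrogen in a ring. Compound 2 has the lowest of the three numbers, but the gap to compound 1 is small: a 2.0-fold lower number from compound 1 to compound 2 (0.30 log units; within the scatter). The gap to compound 3 is a little larger: a 2.0-fold higher number from compound 2 to compound 3 (0.31 log units; beyond the scatter). Between compound 1 and compound 3 the numbers are essentially the same: a 1.0-fold higher number from compound 1 to compound 3 (0.01 log units; within the scatter).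

Compound 4 `COc1ccc(-c2cn3cc(C4=CCN(C(=O)c5cccs5)CC4)ccc3n2)cc1OC` has not yet been measured. It differs from compound 2 in one place: (thiophen-2-yl)carbonyl in place of cyclohexylsulfonyl on an amine nitrogen in a ring. This change takes the cyclohexylsulfonyl group away and brings in an aromatic carbonyl group, which makes compound 4 closer in kind to compound 1, whose (4-chlorophenyl)carbonyl group sits at the same position. The two steps that bear on this, from compound 2 to compound 1 and from compound 2 to compound 3, both moved the number upward by a small amount, one within the scatter and one just beyond it. The expectation for this assay is therefore a modest rise in the number, roughly matching those steps, with no reason in these data to expect a larger move. For compound 4 the expected step is a 1.8-fold higher number from compound 2 to compound 4 (0.25 log units; within the scatter). Compound 4 is thus estimated at 8000 nM, with a likely range from 4000 nM to 16000 nM.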

Compound 4, half-maximal inhibitory concentration: 5200 nM
Compound 4: middle estimate off by 1.5-fold (0.19 log units), on the high side, within the range that was stated.
By their numbers in this assay, from the lowest: compounds 2, 4, 1 and 3 (each within the scatter of the next, the first and the last beyond it).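

In this assay, (thiophen-2-yl)carbonyl in place of cyclohexylsulfonyl on the amine nitrogen in a ring gives a 1.2-fold higher number from compound 2 to compound 4 (0.06 log units; within the scatter), and the new group also stays close to the two other carbonyl-bearing compounds, with a 1.8-fold lower number from compound 3 to compound 4 (0.24 log units; within the scatter) and a 1.7-fold lower number from compound 1 to compound 4 (0.24 log units; within the scatter). On the carbonyl carbon, then, cyclopropyl, 4-chlorophenyl and thiophen-2-yl cannot be told apart in this assay, so a five-membered aromatic ring with a sulfur atom joins a small carbon-only ring and a chlorine-bearing six-membered aromatic ring among groups that give the same reading within the scatter, and the one gap beyond the scatter, between compound 2 and compound 3, now has compound 4 sitting within the scatter of both ends. Nothing measured here offers a cause for these close readings.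

Still open, on these data alone, is whether any group at this nitrogen can move the number well away from this narrow band, for instance a carbonyl group carrying a carboxylic acid, an amine or a longer chain. A plain hydrogen on the nitrogen would also show how much any of these groups contributes at all.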